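The source may hold more compounds than are shown below. What is called first, only, known or untested is meant among the compounds shown, and "the series" means these compounds.

Compound 1 `O=S(=O)(c1cc(Cl)cc(Cl)c1)c1cnc2cc(F)ccc2c1-c1ccccc1F` and compound 2 `O=S(=O)(c1ccc(F)c(Cl)c1)c1cnc2cc(F)ccc2c1-c1ccccc1F` share one core and have both been run in an ADME assay on microsomes from liver (Homo sapiens) for metabolic stability, tested at 2.5 uM; on this read-out higher numbers stand for fast clearance and lower numbers for slow clearance. In this assay, going by the values given here, compound 1 gives 0.93 mL/min, the lowest of the two numbers so far; compound 2 gives 1.07 mL/min. Among the compounds with values here, the single measured step, a 1.2-fold higher number from compound 1 to compound 2 (0.06 log units; within the scatter), concerns only the aryl on the sulfonyl sulfur. Compound 3 `O=S(=O)(c1cc(Cl)cc(Cl)c1)c1cnc2cc(F)ccc2c1-c1cccc(Cl)c1` keeps that 3,5-dichlorophenyl and differs from compound 1 elsewhere on the core: 3-chlorophenyl in place of 2-fluorophenyl on an aromatic carbon. Within the data shown here, no measured step touches this aromatic carbon, so the step from compound 1 to compound 2 bears on the question only loosely, as an example of a halogen swap on an aryl group that stayed within the scatter. On that basis compound 3 is expected to move little, with an estimated step of a 1.2-fold higher number from compound 1 to compound 3 (0.07 log units; within the scatter), no more than the scatter. Compound 3 is accordingly estimated at 1.1 mL/min, within a range from 0.6 mL/min to 2 mL/min.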

Compound 3, intrinsic clearance in a liver preparation (reported as CLH), per the amount of preparation that the assay uses: 0.93 mL/min
Beside the measured number, compound 3's estimate is 1.2-fold (0.07 log units) above it; measured number inside the range.
By their numbers in this assay, from the lowest: compounds 1, 3 and 2 (each within the scatter of the next).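

This aromatic carbon now has its first measured step: in this assay, 3-chlorophenyl in place of 2-fluorophenyl gives no change at the digits printed from compound 1 to compound 3 (within the scatter), so the read-out does not separate these two halogenated phenyl groups. This holds for a single pair, with 3,5-dichlorophenyl kept on the sulfonyl sulfur. No supporting measurement accompanies the result, so nothing can be said about what lies behind it.

Still open, as far as these compounds go, is whether a phenyl carrying a nitrile or a methoxy group, or an amine or a carboxylic acid in place of the phenyl, would stay as close to compound 1 on this carbon. Also open, from the compounds shown here alone, is whether 3-chlorophenyl reads the same with 3-chloro-4-fluorophenyl on the sulfonyl sulfur.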